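The compounds below may be only part of what the source reports. "The series", "measured", "known", "first", "only" and "open" are said of these compounds alone.

Within the data shown here, in a physicochemical assay for solubility, in phosphate buffer, with a stated time of 20 min, tested at 15 uM (on this read-out lower numbers stand for lower solubility and higher numbers for higher solubility), compound 1 (`CC(=O)OC1=C(c2cc(C)nc3ccccc23)Oc2cc3ccccc3cc2-n2cccc21`) gives 340 nM, the higher of the two numbers so far, and compound 2 (`CCc1cc(C2=C(OC(C)=O)c3cccn3-c3cc4ccccc4cc3O2)c2ccccc2n1`) gives 64 nM. Among the measured compounds shown here, the only measured step, a 5.3-fold lower number from compound 1 to compound 2 (0.73 log units; beyond the scatter), came with a methyl in place of hydrogen on a saturated chain carbon. Compound 3 (`CC(=O)OC1=C(c2cccc3cnccc23)Oc2cc3ccccc3cc2-n2cccc21`) differs from compound 1 in another way: isoquinolin-5-yl in place of 2-methylquinolin-4-yl on a double-bonded ring carbon. It carries isoquinolin-5-yl, with no such chain, so that step bears on it only loosely, and a modest rise is expected. The estimated change is a 2.1-fold higher number from compound 1 to compound 3 (0.31 log units; beyond the scatter). For compound 3 the estimated value is 700 nM, with a range of 200 nM to 2500 nM.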

Compound 3, solubility: 220 nM
Beside the measured number, compound 3's estimate is 3.2-fold (0.50 log units) above it, within the range that was stated.
By their numbers in this assay, from the lowest: compound 2; then compounds 3 and 1 (each within the scatter of the next).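

In this assay, isoquinolin-5-yl in place of 2-methylquinolin-4-yl on the double-bonded ring carbon gives a 1.5-fold lower number from compound 1 to compound 3 (0.19 log units; within the scatter) and so leaves the two compounds indistinguishable. Earlier, only a small change on a chain had been seen; here the whole two-ring aromatic group is exchanged for another, with its ring nitrogen elsewhere and without the methyl, and the number stays within the scatter. No measurement shown offers an explanation for this result.

The compounds shown leave open whether a group other than these two-ring aromatics, such as a phenyl ring carrying an amine or a carboxylic acid, would give a number clearly apart from that of compound 1.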